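From Chloro to Iodo on the Shared Core

The compounds below may be only part of what the source reports. "The series", "measured", "known", "first", "only" and "open" are said of these compounds alone.

Compound 3, `CC(CC[C@H]1/C(=C/c2ccc(Cl)cc2)CC[C@H]2C(C)(C)CCC[C@]12C)CC(=O)O`, was tested in a functional assay on THP-1 cells (Homo sapiens) for cytotoxicity, read by MTT assay, with a stated time of 72 h; on this read-out lower numbers stand for stronger inhibition and higher numbers for weaker inhibition. In this assay compound 3 gives only a limit, > 200000 nM. Compound 2, `CC(CC[C@H]1/C(=C/c2ccc(F)cc2)CC[C@H]2C(C)(C)CCC[C@]12C)CC(=O)O`, carries fluoro where compound 3 carries chloro; in this assay compound 2 also gives only a limit, > 200000 nM. Compound 1, `COc1ccc(/C=C2\CC[C@H]3C(C)(C)CCC[C@]3(C)[C@H]2CCC(C)CC(=O)O)cc1OC`, carries a 3,4-dimethoxyphenyl on the double-bonded chain carbon, and in this assay compound 1 gives 106000 nM. The step of an at least 1.8-fold higher number from compound 1 to compound 2 (0.27 log units; that floor lies within the scatter) and the step of an at least 1.8-fold higher number from compound 1 to compound 3 (0.27 log units; that floor lies within the scatter) both run toward the limit, and the step that the two limits leave unreadable from compound 2 to compound 3 cannot be read because both of its ends sit at the limit (the limit of > 200000 nM in this assay, at which 2 of the 3 values shown sit).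

Compound 4, `CC(CC[C@H]1/C(=C/c2ccc(I)cc2)CC[C@H]2C(C)(C)CCC[C@]12C)CC(=O)O`, differs from compound 3 by iodo in place of chloro on an aromatic carbon. Within the data shown here, the only measured step that swaps one halogen for another at this place is the unreadable one between the fluoro and chloro analogues, so no size can be drawn from it; the steps from compound 1 say only that both halogen analogues reach the limit. The step of a number no higher from compound 3 to compound 4 (the limit leaves the size open) is therefore expected to be small, with compound 4 most likely again at or near the limit. Compound 4 is expected to give about 200000 nM in this assay, in a range from 80000 nM to 500000 nM.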

Compound 4, half-maximal inhibitory concentration: 33000 nM
Beside the measured number, compound 4's estimate is 6.1-fold (0.78 log units) above it, outside the stated range (below it).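

At this place on the aromatic ring the halogens are not interchangeable in this assay: iodo in place of chloro gives an at least 6.0-fold lower number from compound 3 to compound 4 (0.78 log units; beyond the scatter), and iodo in place of fluoro gives an at least 6.0-fold lower number from compound 2 to compound 4 (0.78 log units; beyond the scatter), so a halogen swap here now has a readable direction. The 4-iodophenyl group is also the first halogen-bearing group shown to go beyond the scatter from the 3,4-dimethoxyphenyl group of compound 1, with a 3.2-fold lower number from compound 1 to compound 4 (0.51 log units; beyond the scatter), whereas the fluoro and chloro analogues gave only limits. The two steps to compound 4 remain floors and not sizes, and the step between the fluoro and chloro analogues cannot be read, because both of those compounds sit at the limit of the assay: the limit of > 200000 nM in this assay, at which 2 of the 4 values shown sit.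

The compounds shown leave open whether a bromo at this place would stay at the limit with chloro or give a lower number with iodo, and so whether the change belongs to iodo alone or runs through the halogens. They also leave open whether a group that is not a halogen, such as a nitrile or a single methoxy, could match iodo here, and whether iodo would hold its lower number with a methyl ester in place of the free acid.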